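This account rests on a few compounds, and the source may have more. Where it says the series, first, only, none or still open, it means among the compounds named here.

Of the compounds shown here, three that share a core have been measured in a functional assay on A-375 cells (Homo sapiens), read by thymidine incorporation; on this read-out higher numbers stand for weaker inhibition and lower numbers for stronger inhibition. Compound 1 `CCCCCCCC/C=C\CCCCCCCC(=O)N[C@H]1[C@@H](OCCCCCCCC)O[C@H](CO)[C@@H](O)[C@@H]1O` gives 6 uM. Compound 2 `CCCCCCCCCCCCCCCCO[C@H]1O[C@H](COC[C@H](O)CO)[C@@H](O)[C@H](O)[C@H]1NC(=O)CCCC` gives 2.2 uM, and compound 3 `CCCCCCCC/C=C\CCCCCCCC(=O)N[C@H]1[C@@H](OCCCCCCCC)O[C@H](CO)[C@@H](O)[C@@H]1OS(=O)(=O)O` gives 16 uM. On these numbers compound 1 stands second highest of the three, with compound 3 the nearest of the other two and compound 2 the furthest. Within the data shown here, only one step between measured compounds rests on a single change: a 2.7-fold higher number from compound 1 to compound 3 (0.43 log units; beyond the scatter), where a sulfo group replaces a hydrogen on an oxygen on a saturated carbon of the shared core.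

Compound 4 `CCCCCCCC/C=C\CCCCCCCC(=O)N[C@H]1[C@@H](OCCCCCCCC)O[C@H](COS(=O)(=O)O)[C@@H](O)[C@@H]1O` differs from compound 1 in the same kind of way: sulfo in place of hydrogen on an oxygen on a saturated carbon. Here the hydroxymethyl becomes (sulfooxy)methyl. Among the measured compounds shown here, the step from compound 1 to compound 3 is the only measured step that bears on this change, and it raised the number modestly, beyond the scatter. A similar modest rise is expected for compound 4 because a 2.7-fold higher number from compound 1 to compound 3 (0.43 log units; beyond the scatter) shows the same addition at another oxygen of the core weakening inhibition. The expected step is therefore a 2.2-fold higher number from compound 1 to compound 4 (0.34 log units; beyond the scatter) in this assay. Compound 4 is estimated to give 13 uM in this assay, within a range from 5 uM to 35 uM.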

Compound 4, concentration for 50% inhibition: 15.6 uM
Beside the measured number, compound 4's estimate is 1.2-fold (0.08 log units) below it; measured number inside the range.
By their numbers in this assay, from the lowest: compound 2; then compound 1; then compounds 4 and 3 (each within the scatter of the next).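

In this assay, the change from hydroxymethyl to (sulfooxy)methyl brings a 2.6-fold higher number from compound 1 to compound 4 (0.41 log units; beyond the scatter), so the sulfo group on this oxygen comes with weaker inhibition. Until now, the only view of this addition came from a different oxygen of the shared core, with a 2.7-fold higher number from compound 1 to compound 3 (0.43 log units; beyond the scatter); the two steps are close in size and point the same way, so the rise is not confined to a single oxygen in this pair of examples. Nothing measured here explains the rise at either oxygen.

On these data alone, it remains open whether the rise belongs to the sulfo group specifically or would also follow from other groups on this oxygen, such as a methyl ether, an acetate ester or a phosphate, or from a carboxylic acid in place of the hydroxymethyl. Also open, as far as these compounds go, is what sulfo groups on both oxygens at once would do, and whether the same step would appear on a core carrying the hexadecyl ether and short amide chain of compound 2.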